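The compounds below may be only part of what the source reports. "The series", "measured", "known", "first", "only" and "open" are said of these compounds alone.

In a functional assay on VCaP cells (Homo sapiens) for antiproliferative activity, read by propidium iodide staining, with a stated time of 96 h (on this read-out lower numbers stand for stronger inhibition and higher numbers for weaker inhibition), compound 1 (`CC(O)(COc1cccc(OC(F)(F)F)c1)C(=O)Nc1cccc(S(F)(F)(F)(F)F)c1`) gives 28600 nM. Compound 2 (`CC(O)(CS(=O)(=O)c1cccc(S(F)(F)(F)(F)F)c1)C(=O)Nc1ccc(C#N)cc1C(F)(F)F`), which has a different structure on both sides of the shared hydroxy amide chain, gives 20800 nM. These two numbers lie within the usual scatter of repeated measurements, so the data do not separate the two compounds, and neither can be ranked above the other.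

Compound 3 (`CC(O)(CS(=O)(=O)c1cccc(S(F)(F)(F)(F)F)c1)C(=O)Nc1ccc([N+](=O)[O-])cc1C(F)(F)F`) keeps everything in compound 2 except one group, with nitro in place of cyano on an aromatic carbon, meta to a trifluoromethyl group and para to a large group (nitro in place of cyano on an aromatic carbon). Going by the values given here, no measured pair in this small set shows what such an exchange does in this assay, so no step beyond the scatter is expected in either direction. The expectation therefore stays anchored on compound 2 at 20800 nM. The expected change, a 1.2-fold lower number from compound 2 to compound 3 (0.06 log units; within the scatter), is small and within the scatter. For compound 3 the estimated value is 18000 nM, with an expected range from 7000 nM to 40000 nM.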

Compound 3, half-maximal inhibitory concentration: 100000 nM
For compound 3 the middle estimate is 5.6-fold (0.74 log units) below the measured one, outside the stated range (above it).
By their numbers in this assay, from the lowest: compounds 2 and 1 (each within the scatter of the next); then compound 3.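

In this assay, putting nitro in place of cyano on the aromatic carbon, meta to a trifluoromethyl group and para to a large group, gives a 4.8-fold higher number from compound 2 to compound 3 (0.68 log units; beyond the scatter), a modest step but one beyond the scatter. Going by these compounds alone, this single exchange is the first readable evidence that this position is not indifferent to the group it carries, since nitro goes with weaker inhibition than cyano while the rest of the structure stays the same, something the comparison of compound 1 and compound 2, which differ in more than one place, could not show. Nothing in the data explains the size or the direction of this step.

The compounds shown leave open how other groups on this carbon, such as an amine, a carboxylic acid or a single fluorine atom, would compare with cyano in this assay. They also leave open whether the exchange of cyano for nitro would give a step of similar size if another part of compound 2 were changed, for example with a longer chain in place of the methyl group on the hydroxy amide chain.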